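Cyanopyridinyl in place of pyridinyl on the piperazine amide

This account rests on a few compounds, and the source may have more. Where it says the series, first, only, none or still open, it means among the compounds named here.

Compound 1 `O=C(COCc1ccccc1)N1CCN(c2cccnc2)CC1` is the reference point of this series. In a functional assay on HEK293 cells for positive allosteric modulation of metabotropic glutamate receptor 5 (Rattus norvegicus), read by fluorescence and calcium flux (a higher number here means that more compound is needed for the effect, a lower number that less compound is needed), compound 1 is recorded as "not active" (no number reported), so no number places it. Among the compounds with values here, the only measured value in the set belongs to compound 2 `O=C(COCc1ccccc1)N1CCN(c2ccccc2[N+](=O)[O-])CC1`, which in this assay gives 1800 nM. Compound 3 `N#Cc1cccnc1N1CCN(C(=O)COCc2ccccc2)CC1` differs from compound 1 in one place: 3-cyanopyridin-2-yl in place of pyridin-3-yl on an amine nitrogen in a ring. Within the data shown here, no measured step covers this change, so its size is uncertain; the expectation is that compound 3 moves from inactivity to a measurable number, with a real chance that only a limit is reported. Compound 3 is expected to give 2000 nM in this assay, within 600 nM to 8000 nM.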

Compound 3, half-maximal effective concentration: > 10000 nM
Compound 3 ended at the assay's limit; the forecaster's own chance of this, stated with the estimate: 40%; middle value at least 5.0-fold (0.69 log units) away from the limit.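

In this assay compound 3 gives > 10000 nM, a limit and not a number. With no number for compound 1 either, no step can be read between compound 1 and compound 3. From the compounds shown here alone, whether pyridin-3-yl or 3-cyanopyridin-2-yl on the shared core can give a measurable value in this assay stays open.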